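This account rests on a few compounds, and the source may have more. Where it says the series, first, only, none or still open, it means among the compounds named here.

Measured compounds in an assay on cells for positive allosteric modulation of Cystic fibrosis transmembrane conductance regulator variant F508del (Homo sapiens), with stated times of 10 min and 7 s, in the presence of a further agent that is not named here; on this read-out higher numbers stand for an effect only at larger amounts of compound and lower numbers for an effect already at smaller amounts:
compound 1 `CC1(C)Cc2c(sc(NC(=O)C3CCNC3=O)c2C(N)=O)C(C)(C)O1` gives 101 nM
compound 2 `CC1(C)Cc2c(sc(NC(=O)C3(CO)CC3)c2C(N)=O)C(C)(C)O1` gives 15 nM
compound 3 `CC1(C)Cc2c(sc(NC(=O)c3[nH]ncc3Cl)c2C(N)=O)C(C)(C)O1` gives 2 nM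

Compound 3 stands at the lowest number of the three. Its nearest neighbour is compound 2, with a 7.5-fold lower number from compound 2 to compound 3 (0.88 log units; beyond the scatter); the furthest is compound 1, with a 51-fold lower number from compound 1 to compound 3 (1.70 log units; beyond the scatter). Both steps exchange the whole group on the carbonyl carbon, and both move from a non-aromatic ring to the five-membered aromatic ring of compound 3. The step of a 6.7-fold lower number from compound 1 to compound 2 (0.83 log units; beyond the scatter) exchanges two non-aromatic groups.

Compound 4 `Cc1cc(C(=O)Nc2sc3c(c2C(N)=O)CC(C)(C)OC3(C)C)[nH]n1` is the next one to be measured. It differs from compound 3 by a group of 6 heavy atoms (4 carbon, 2 nitrogen; one five-membered aromatic ring with 2 hetero atoms) in place of a group of 6 heavy atoms (3 carbon, 2 nitrogen, 1 chlorine; one five-membered aromatic ring with 2 hetero atoms), on a carbonyl carbon. None of the three measured steps bears on this change: each of them replaces the whole ring, while here the five-membered aromatic ring with 2 hetero atoms is kept and only its substituent is exchanged. With no step of this kind shown, the expectation for compound 4 is a number near that of compound 3, with at most a small shift in either direction, so the step is estimated as a 2.0-fold higher number from compound 3 to compound 4 (0.30 log units; within the scatter). Compound 4 is therefore expected at 4 nM in this assay, within 1.5 nM to 12 nM.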

Compound 4, half-maximal effective concentration: 13 nM
Compound 4: the middle estimate sits 3.3-fold (0.51 log units) below what was measured; the whole stated range lies below it.
By their numbers in this assay, from the lowest: compound 3; then compounds 4 and 2 (each within the scatter of the next); then compound 1.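

Keeping the five-membered aromatic ring with 2 hetero atoms does not by itself keep the number in this assay: a 6.5-fold higher number from compound 3 to compound 4 (0.81 log units; beyond the scatter), so exchanging only what the ring carries gives a step beyond the scatter. An aromatic ring on the carbonyl carbon also does not set a group apart from a non-aromatic one, since a 1.2-fold lower number from compound 2 to compound 4 (0.06 log units; within the scatter), while a 7.8-fold lower number from compound 1 to compound 4 (0.89 log units; beyond the scatter) shows that 3-methyl-1H-pyrazol-5-yl still differs clearly from 2-oxopyrrolidin-3-yl. Nothing measured here gives a reason for these steps.

Still open, going by these compounds, is how a 1H-pyrazol-5-yl ring with no substituent would stand against compound 3 and compound 4. Also open, on these data alone, is whether methyl placed where compound 3 has its chlorine, or bromine, trifluoromethyl or an amine there, would follow the chlorine or the 3-methyl group.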